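Replacing 4-methylpiperazin-1-yl with dimethylamino in compound 2

The compounds below may be only part of what the source reports. "The series", "measured", "known", "first", "only" and "open" are said of these compounds alone.

Measured in a functional assay (Homo sapiens) for inhibition, read by sulforhodamine B assay, with a stated time of 3 days; a lower number here means a stronger inhibitor, a higher number a weaker inhibitor:
- compound 1 `CN(C)c1nc2nc(N3CCNCC3)nc(N3CCCC3)c2nc1Cl` gives 5800 nM
- compound 2 `CN1CCN(c2nc(N3CCCC3)c3nc(Cl)c(NCc4ccccc4)nc3n2)CC1` gives 6500 nM

The two values lie within the usual scatter of each other, so compound 2 stands level with compound 1. Compound 3 `CN(C)c1nc(N2CCCC2)c2nc(Cl)c(NCc3ccccc3)nc2n1` has dimethylamino in place of 4-methylpiperazin-1-yl on an aromatic carbon and has not yet been measured. Among the measured compounds shown here, no measured pair isolates this change. A small step toward a weaker number, probably within the scatter, is expected (a 1.4-fold higher number from compound 2 to compound 3 (0.14 log units; within the scatter)). Compound 3 is estimated at 9000 nM (expected range 3500 nM to 25000 nM).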

Compound 3, half-maximal inhibitory concentration: 11800 nM
Compound 3: the middle estimate sits 1.3-fold (0.12 log units) below what was measured; the range from low to high includes it.
By their numbers in this assay, from the lowest: compounds 1, 2 and 3 (each within the scatter of the next, the first and the last beyond it).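

In this assay, dimethylamino in place of 4-methylpiperazin-1-yl on this aromatic carbon, between two ring nitrogen atoms, gives a 1.8-fold higher number from compound 2 to compound 3 (0.26 log units; within the scatter), so this single change is now read directly. At this position, the six-membered non-aromatic ring can give way to an open dimethylamino group with no step beyond the scatter. No measurement at hand bears on the size of this step.

As far as these compounds go, how morpholin-4-yl, a primary amine or a longer chain ending in a carboxylic acid would read at this place remains open. Also open, from the compounds shown here alone, is whether the step holds when the pyrrolidin-1-yl group is replaced.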